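From acid to ethyl ester on compound 1

The compounds below may be only part of what the source reports. "The series", "measured", "known", "first", "only" and "open" are said of these compounds alone.

Values in a functional assay on the whole organism (strain Sprague-Dawley) for inhibition, with Rattus norvegicus as the target, with a stated time of 10 min; a higher number here means that more compound is needed for the effect, a lower number that less compound is needed:
Compound 1 `CCOc1ccc(N)cc1-c1ncc(C(=O)O)c(=O)[nH]1` gives 1.2 mg/kg
Compound 2 `CCOc1ccc(N(C)C)cc1-c1ncc(C(=O)O)c(=O)[nH]1` gives 0.3 mg/kg
Compound 3 `CCOc1ccc(S(N)(=O)=O)cc1-c1ncc(C(=O)O)c(=O)[nH]1` gives > 50 mg/kg as a limit of the assay, not a number

Only two of these are actual numbers, and the gap between them is a 4.0-fold lower number from compound 1 to compound 2 (0.60 log units; beyond the scatter), which leaves compound 1 with the higher one.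

Compound 4 `CCOC(=O)c1cnc(-c2cc(N)ccc2OCC)[nH]c1=O` keeps the core of compound 1 but has ethyl in place of hydrogen on an oxygen next to a carbonyl group, so carboxy becomes ethoxycarbonyl (ethyl in place of hydrogen on an oxygen next to a carbonyl group).

Going by the values given here, no measured step touches this group. All measured steps change the amino group instead, and the other one from compound 1 is large (an at least 41-fold higher number from compound 1 to compound 3 (1.61 log units; beyond the scatter)). Among the compounds with values here, they show only that a single change can move the number a long way in this assay. All three measured compounds keep the free carboxy group, so the direction is a cautious guess. The expected move is a 3.3-fold higher number from compound 1 to compound 4 (0.52 log units; beyond the scatter), with wide uncertainty. For compound 4 the estimated value is 4 mg/kg, expected to lie between 0.8 mg/kg and 40 mg/kg, pending measurement.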

Compound 4, dose for 50% inhibition: 0.5 mg/kg
Compound 4: middle estimate off by 8.0-fold (0.90 log units), on the high side; the measured number lies below the stated range.
By their numbers in this assay, from the lowest: compounds 2 and 4 (each within the scatter of the next); then compound 1. At a limit, above all of these: compound 3.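

Turning carboxy into ethoxycarbonyl gives, in this assay, a 2.4-fold lower number from compound 1 to compound 4 (0.38 log units; beyond the scatter). So in the compounds shown, the free carboxy group is not needed for the effect, and the hydrogen on this oxygen can be replaced by ethyl without losing it. Nothing shown bears on why this change moves the number.

From the compounds shown here alone, it remains open whether a methyl ester, a longer chain such as butyl, or an amide in place of ethoxycarbonyl would behave the same way. Going by these compounds, the same ethyl on compound 2 also remains untested here.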